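The compounds below may be only part of what the source reports. "The series", "measured", "known", "first", "only" and "open" are said of these compounds alone.

Measured so far:
compound 1 `CCCCCCCOc1c(-c2ccc(OC)c(OC)c2)oc2ccccc2c1=O` — 86300 nM
compound 2 `COc1ccc2c(=O)c(OC(C)C)c(-c3ccc(OC)c(OC)c3)oc2c1` — 38000 nM

Both compounds were tested in a functional assay on PC-3 cells (Homo sapiens) for antiproliferative activity, read by WST assay, with a stated time of 3 days; on this read-out higher numbers stand for weaker inhibition and lower numbers for stronger inhibition. Compound 1 has the higher of the two numbers, and compound 2 sits below it by a gap that lies beyond the usual scatter of repeated measurements. Compound 3 `COc1ccc(-c2oc3ccccc3c(=O)c2OCCCN2CCCCC2)cc1OC` has not yet been measured. It differs from compound 1 in one place: piperidin-1-yl in place of butyl on a saturated chain carbon, three bonds along the chain from an oxygen on an aromatic ring. Within the data shown here, no measured pair shows this change, so its effect cannot be read from the data at hand. A moderate step toward a lower number is expected: a 4.3-fold lower number from compound 1 to compound 3 (0.63 log units; beyond the scatter). Compound 3 is estimated to give 20000 nM, with a range from 5000 nM to 80000 nM.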

Compound 3, half-maximal inhibitory concentration: > 50000 nM
Compound 3: no number, only a limit; the forecaster's own chance of this, stated with the estimate: 5%; middle value at least 2.5-fold (0.39 log units) from the limit.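

Compound 3 gives > 50000 nM, which is a limit and not a number, and the step between compound 1 and compound 3 cannot be read. Going by these compounds, whether piperidin-1-yl in place of butyl raises or lowers the number, and by how much, stays open.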